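Pyridin-4-yl to pyridin-3-yl: expected lipophilicity shift

A few compounds are considered here, and "the series" means these few. Any claim that something is new, unique, unknown or untested is made for them only; others in the source may bear on it.

Measured so far in a physicochemical assay for lipophilicity, at pH 7.4; on this read-out higher numbers stand for higher lipophilicity and lower numbers for lower lipophilicity:
compound 1 `CNC(=O)c1cc(C(=O)NC2CCC2)cn(Cc2ccncc2)c1=O` gives 1.7
compound 2 `CNC(=O)c1cc(C(=O)NC2CC2)cn(CC2CCCOC2)c1=O` gives 2
compound 3 `CNC(=O)c1cc(C(=O)NC2CC2)c(C)n(Cc2ccccc2)c1=O` gives 2.9

Compound 1 sits at the low end of the three numbers in this assay. Its gap to compound 2 lies within the scatter, so the two are not distinguished; compound 3 stands beyond the scatter above it.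

Compound 4 `CNC(=O)c1cc(C(=O)NC2CCC2)cn(Cc2cccnc2)c1=O` is not yet measured. It differs from compound 1 by pyridin-3-yl in place of pyridin-4-yl on a saturated chain carbon bound to an aromatic nitrogen.

For the measured compounds named here, no measured pair shows this change, so no step is available as a guide. For compound 4 a small upward shift, within the scatter, is estimated: a number 0.10 log units higher from compound 1 to compound 4 (within the scatter). Compound 4 is expected at 1.8, between 1.4 and 2.2.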

Compound 4, distribution coefficient: 1.8
For compound 4 middle estimate and measured number coincide at the digits printed; measured number inside the range.
By their numbers in this assay, from the lowest: compounds 1, 4 and 2 (each within the scatter of the next); then compound 3.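

In this assay, pyridin-3-yl in place of pyridin-4-yl on a saturated chain carbon bound to an aromatic nitrogen gives a number 0.10 log units higher from compound 1 to compound 4 (within the scatter) and so leaves the two compounds undistinguished. For the compounds shown here, this is the first pair that differs in one place, and it shows that the swap between these two pyridine isomers does not separate compounds on this read-out. Nothing at hand explains the result.

Open, on these data alone, is whether pyridin-2-yl or a longer chain ending in a dimethylamino group at this place would give a step beyond the scatter. Also open, as far as these compounds go, is whether the same swap reads alike on the core of compound 3.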